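A few compounds are considered here, and "the series" means these few. Any claim that something is new, unique, unknown or untested is made for them only; others in the source may bear on it.

Measured so far:
- compound 1 `Cc1ccc(-c2nnc(-n3[se]c4ccccc4c3=O)s2)cc1`: in a functional assay on SSMC-7721 cells (Homo sapiens) for antiproliferative activity, read by CCK-8 assay, with a stated time of 48 h (on this read-out higher numbers stand for weaker inhibition and lower numbers for stronger inhibition), compound 1 gives 16600 nM
- compound 2 `COc1ccc(-c2nnc(-n3[se]c4ccccc4c3=O)s2)cc1`: in this assay compound 2 gives 16500 nM
- compound 3 `O=c1c2ccccc2[se]n1-c1nnc(-c2ccc(F)cc2)s1`: in this assay compound 3 gives 42900 nM

Compound 3 stands highest of the three numbers: a 2.6-fold higher number from compound 1 to compound 3 (0.41 log units; beyond the scatter) and a 2.6-fold higher number from compound 2 to compound 3 (0.41 log units; beyond the scatter), both beyond the scatter, while a 1.0-fold lower number from compound 1 to compound 2 (0.00 log units; within the scatter). The next compound, compound 4 `Cc1ccccc1-c1nnc(-n2[se]c3ccccc3c2=O)s1`, differs from compound 3 in one place: 2-methylphenyl in place of 4-fluorophenyl on an aromatic carbon. Within the data shown here, two measured steps bear on this change, since each put fluoro in place of methyl or methoxy and each raised the number modestly: a 2.6-fold higher number from compound 1 to compound 3 (0.41 log units; beyond the scatter) and a 2.6-fold higher number from compound 2 to compound 3 (0.41 log units; beyond the scatter). Taking the fluoro away again and bringing back a methyl would, by that reasoning, lower the number by a similar modest amount. Going by these compounds, the entering 2-methylphenyl is not the group borne by compound 1, however, so the size of the fall is untested. A modest fall beyond the scatter is therefore expected, and no more. Compound 4 is estimated at 20000 nM with a range of 9000 nM to 45000 nM, which means an expected step of a 2.1-fold lower number from compound 3 to compound 4 (0.33 log units; beyond the scatter).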

Compound 4, half-maximal inhibitory concentration: 19400 nM
The estimate for compound 4 lay 1.0-fold (0.01 log units) above the measured number; the range from low to high includes it.
By their numbers in this assay, from the lowest: compounds 2, 1 and 4 (each within the scatter of the next); then compound 3.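

In this assay, among these compounds, 2-methylphenyl in place of 4-methylphenyl gives a 1.2-fold higher number from compound 1 to compound 4 (0.07 log units; within the scatter) and so does not separate these two methylphenyl groups, a comparison the earlier compounds, all with groups named or drawn on the same phenyl carbon, could not offer. 2-methylphenyl in place of 4-fluorophenyl gives a 2.2-fold lower number from compound 3 to compound 4 (0.34 log units; beyond the scatter). Among the compounds shown here, this places compound 4 with compounds 1 and 2, leaving compound 3, the only fluorinated member, apart from the other three. The data at hand offer no measurement that accounts for either step.

Going by these compounds, whether 2-fluorophenyl would fall with compound 3 or with compound 4 remains open. Also open, on these data alone, is whether an amine, a carboxylic acid or a longer chain on the phenyl ring would move the number beyond the scatter of this group of compounds.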